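A Chlorothiophene for a Methylthiophene: Expected Inhibition

This account rests on a few compounds, and the source may have more. Where it says the series, first, only, none or still open, it means among the compounds named here.

Of the compounds shown here, two sharing one core have been measured in an assay on isolated protein for inhibition of DNA topoisomerase 1 (Homo sapiens), with a stated time of 30 min, tested at 100 uM; on this read-out higher numbers stand for more inhibition at the one concentration tested (going by the name of the read-out) and lower numbers for less inhibition. Compound 1 `Clc1ccc(-c2cc(-c3ccoc3)cc(-c3ccco3)n2)s1` gives 9.6% in this assay. Compound 2 `Cc1ccsc1-c1cc(-c2ccc(Cl)o2)cc(-c2ccco2)n1` gives 7.8% in this assay, the lower of the two numbers, but its nearest neighbour is compound 1 and the gap to it lies within the scatter, so the two read as equivalent. Compound 3 `Clc1ccc(-c2cc(-c3ccco3)nc(-c3ccc(Cl)s3)c2)o1` has not yet been measured. It differs from compound 2 in one place: 5-chlorothiophen-2-yl in place of 3-methylthiophen-2-yl on an aromatic carbon. Among the compounds with values here, no step between measured compounds with a comparable change is available, so the expectation rests on the two numbers alone. Since compound 1 and compound 2 both sit at low inhibition, compound 3 is expected to stay in the same region, with a step of a number 1.2 percentage points higher from compound 2 to compound 3 (within the scatter) that is not expected to exceed the scatter. Compound 3 is therefore estimated at 9%, with a range from 0% to 25%.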

Compound 3, a percentage reported as inhibition, at one concentration (the size of the read-out at that concentration, not a potency): 23.1%
For compound 3 the middle estimate is 14.1 percentage points below the measured one; measured number inside the range.
By their numbers in this assay, from the lowest: compounds 2 and 1 (each within the scatter of the next); then compound 3.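

Replacing 3-methylthiophen-2-yl with 5-chlorothiophen-2-yl on the aromatic carbon next to the ring nitrogen gives a number 15.3 percentage points higher from compound 2 to compound 3 (beyond the scatter) in this assay, so this position responds to the group it carries, which the two earlier compounds, equivalent within the scatter, could not show. A second single change, 5-chlorofuran-2-yl in place of furan-3-yl on an aromatic carbon, gives a number 13.5 percentage points higher from compound 1 to compound 3 (beyond the scatter), so two separate one-place changes both lead to a modest rise at compound 3. No measurement bears on what lies behind either step.

The compounds shown leave open whether the chlorine itself or its place on the thiophene carries the step, and what compound 3 would show as a potency rather than at one concentration. Also open, going by these compounds, is how an amine or a carboxylic acid on that thiophene would read.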